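This account rests on a few compounds, and the source may have more. Where it says the series, first, only, none or still open, it means among the compounds named here.

Measured in a functional assay on Jurkat cells (Homo sapiens); a higher number here means a weaker inhibitor, a lower number a stronger inhibitor:
- Compound 1 `Cc1cccc(CNC(=O)C(=O)N[C@@H](C)C(=O)N[C@@H](CC(=O)O)C(=O)COc2c(F)c(F)cc(F)c2F)c1C`: 102 nM
- Compound 2 `C[C@H](NC(=O)C(=O)NCc1ccc(Cl)cc1Cl)C(=O)N[C@@H](CC(=O)O)C(=O)COc1c(F)c(F)cc(F)c1F`: 165 nM
- Compound 3 `C[C@H](NC(=O)C(=O)NCc1c(Cl)cccc1Cl)C(=O)N[C@@H](CC(=O)O)C(=O)COc1c(F)c(F)cc(F)c1F`: 110 nM

These three compounds differ only in the substituted phenyl group on a saturated chain carbon bound to an amide-type nitrogen. Compound 3, at 110 nM, cannot be ranked against the other two. The data show a 1.1-fold higher number from compound 1 to compound 3 (0.03 log units; within the scatter) and a 1.5-fold lower number from compound 2 to compound 3 (0.18 log units; within the scatter), and both steps are within the normal scatter of repeated measurements.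

For the measured compounds named here, compound 4 `C[C@H](NC(=O)C(=O)NCc1cc(F)cc(F)c1)C(=O)N[C@@H](CC(=O)O)C(=O)COc1c(F)c(F)cc(F)c1F` keeps the shared core and changes only that group, with 3,5-difluorophenyl in place of 2,6-dichlorophenyl on a saturated chain carbon bound to an amide-type nitrogen.

The measured steps that bear on this swap are the two above and a 1.6-fold higher number from compound 1 to compound 2 (0.21 log units; within the scatter), all made at the same place. None of them goes beyond the scatter, so a change of this group has not yet shifted the number in a way that can be distinguished from noise. However, no measured compound carries fluorine on this phenyl group, so the new group is untested and the range must stay wide.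

No step beyond the scatter is expected, and the expected change is a 1.1-fold higher number from compound 3 to compound 4 (0.04 log units; within the scatter). For compound 4 the estimated value is 120 nM, with an expected range of 50 nM to 290 nM.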

Compound 4, half-maximal inhibitory concentration: 16 nM
Compound 4: the middle estimate sits 7.5-fold (0.88 log units) above what was measured; measured number outside the range, below it.
By their numbers in this assay, from the lowest: compound 4; then compounds 1, 3 and 2 (each within the scatter of the next).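

In this assay, this position proves able to move the number: 3,5-difluorophenyl gives a 6.9-fold lower number from compound 3 to compound 4 (0.84 log units; beyond the scatter), and the comparisons with the other two groups give a 10-fold lower number from compound 2 to compound 4 (1.01 log units; beyond the scatter) and a 6.4-fold lower number from compound 1 to compound 4 (0.80 log units; beyond the scatter). The 2,3-dimethylphenyl, 2,4-dichlorophenyl and 2,6-dichlorophenyl groups all lie within the scatter of one another, so they gave no sign of this, whereas compound 4 now stands apart from all three as the strongest inhibitor of the four. Nothing available explains the gain, and the data alone cannot say how this group achieves it.

The change from compound 3 to compound 4 alters two things at once, the halogen (fluorine for chlorine) and the numbers in the group's name, so the compounds shown cannot separate the contribution of each. A 3,5-dichlorophenyl group would keep the numbering with chlorine and a 2,6-difluorophenyl group would keep fluorine with the earlier numbering, so these two would show which of the changes matters, while a 3-fluorophenyl group would test whether a single fluorine is enough.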